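Free acid in place of the methylbenzyl amide

The compounds below may be only part of what the source reports. "The series", "measured", "known", "first", "only" and "open" are said of these compounds alone.

Compound 3 `C=CC1=C(C(=O)NCc2ccc(C)cc2)C(c2ccc(OC)c(OC)c2)OC1` sits at the weak end of the numbers shown: in a functional assay on HeLa cells (Homo sapiens) for cytotoxicity, read by MTT assay, with a stated time of 24 h (on this read-out higher numbers stand for weaker inhibition and lower numbers for stronger inhibition), compound 3 gives only a limit of the assay, > 100000 nM, and (the limit of > 100000 nM in this assay, at which 1 of the 3 values shown sits). For the measured compounds named here, compound 2 `C=CC1=C(C(=O)NC2CCCCC2)C(c2ccc(OC)c(OC)c2)OC1` gives 5540 nM in the same read-out, and the one measured step that reaches compound 3, an at least 18-fold higher number from compound 2 to compound 3 (1.25 log units; beyond the scatter), is large and concerns the substituent on the amide nitrogen only. Compound 1 `C=CC1=C(C(=O)O)C(c2ccc(OC)cc2)OC1`, a free acid on a different aryl group, gives 44300 nM. Compound 4 `C=CC1=C(C(=O)O)C(c2ccc(OC)c(OC)c2)OC1` has not been measured. The change from compound 3 to compound 4 is hydroxy in place of (4-methylbenzyl)amino on a carbonyl carbon. Going by the values given here, no measured step covers the move from an amide to the free acid, so the expectation rests on compound 1, whose value 44300 nM is the only number for an acid of this core. Compound 4 is therefore expected to return from the limit into the measurable range, at an estimated 40000 nM (range 12000 nM to 130000 nM), which means an expected step of an at least 2.5-fold lower number from compound 3 to compound 4 (0.39 log units; beyond the scatter), though a further limit value remains possible.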

Compound 4, half-maximal inhibitory concentration: 18000 nM
Beside the measured number, compound 4's estimate is 2.2-fold (0.35 log units) above it; the range from low to high includes it.
By their numbers in this assay, from the lowest: compound 2; then compound 4; then compound 1. At a limit, above all of these: compound 3.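

In this assay, hydroxy in place of (4-methylbenzyl)amino on the carbonyl carbon gives an at least 5.5-fold lower number from compound 3 to compound 4 (0.74 log units; beyond the scatter), and this step is read against a limit of the assay, not a number: the limit of > 100000 nM in this assay, at which 1 of the 4 values shown sits. Hydroxy in place of cyclohexylamino gives a 3.2-fold higher number from compound 2 to compound 4 (0.51 log units; beyond the scatter), so at this position the free acid falls between the two amides, and the amide as such does not set the direction of the change. Methoxy in place of hydrogen on an aromatic carbon gives a 2.5-fold lower number from compound 1 to compound 4 (0.39 log units; beyond the scatter), the first reading of that aryl change, and it comes from the acids alone.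

As far as these compounds go, whether the same aryl change holds among the amides remains open. From the compounds shown here alone, it is also open where a methyl ester or an unsubstituted benzyl amide would fall relative to the acid.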